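This account rests on a few compounds, and the source may have more. Where it says the series, first, only, none or still open, it means among the compounds named here.

Compound 1 `CCCn1c(=O)[nH]c2nc(-c3ccc(S(=O)(=O)N4CCN(c5ccc(Br)cc5)CC4)cc3)[nH]c2c1=O`: in an assay on CHO cells for displacement of a labelled ligand from adenosine receptor A1 (Homo sapiens), read by scintillation counting, with a stated time of 90 min, in the presence of a further agent that is not named here (a lower number here means a stronger inhibitor, a higher number a weaker inhibitor), compound 1 gives only a limit, > 1000 nM.
Compound 2 `CCCn1c(=O)[nH]c2nc(-c3ccc(S(=O)(=O)N4CCN(Cc5ccc(Br)c(F)c5)CC4)cc3)[nH]c2c1=O`: in this assay compound 2 gives 326 nM.

Compound 2 holds the only number shown; the other value is a limit (the limit of > 1000 nM in this assay, at which 1 of the 2 values shown sits). Compound 3 `CCCn1c(=O)[nH]c2nc(-c3ccc(S(=O)(=O)N4CCN(c5ccc(I)cc5)CC4)cc3)[nH]c2c1=O` differs from compound 2 by 4-iodophenyl in place of 4-bromo-3-fluorobenzyl on an amine nitrogen in a ring. Among the measured compounds shown here, the single measured step bears on this in reverse: an at least 3.0-fold lower number from compound 1 to compound 2 (0.48 log units; beyond the scatter) replaced an aryl group on that nitrogen with a benzyl group, and compound 3 returns to an aryl group there, as in compound 1. A step of roughly that size back toward a higher number is therefore expected, a 4.6-fold higher number from compound 2 to compound 3 (0.66 log units; beyond the scatter). Compound 3 is estimated at 1500 nM, between 500 nM and 5000 nM, with a fair chance that only a limit is reported.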

Compound 3, inhibition constant: > 1000 nM
Compound 3 gave a limit, no number; the forecaster's own chance of this, stated with the estimate: 60%; the middle value lies beyond the limit too.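

In this assay, 4-iodophenyl in place of 4-bromo-3-fluorobenzyl on the amine nitrogen gives an at least 3.0-fold higher number from compound 2 to compound 3 (0.48 log units; beyond the scatter), so a second aryl group on that nitrogen also falls short of compound 2. Compound 3 gives only a limit, as compound 1 does, and iodo in place of bromo on the aromatic carbon yields no number: the limit of > 1000 nM in this assay, at which 2 of the 3 values shown sit. The step from compound 1 to compound 3 cannot be read.

From the compounds shown here alone, it remains open whether the lower number of compound 2 goes with the benzyl group itself or with its fluoro, and how an unsubstituted benzyl or a phenethyl group on that nitrogen would read in this assay.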